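The source may report more compounds than this note shows. Statements on the series, on what has been measured and on what is new or still open speak of the compounds shown alone.

Among the compounds with values here, only two compounds have been tested so far in a functional assay on the whole organism with Mus musculus as the target (a higher number here means that more compound is needed for the effect, a lower number that less compound is needed), and neither gave a number. Compound 1 `N=c1c2ncn(C3O[C@H](CO)[C@@H](O)[C@H]3O)c2[nH]c(=O)n1-c1ccccc1` reached only a limit of the assay, > 100 mg/kg. Compound 2 `Cn1c(=O)[nH]c2c(nc(Br)n2C2O[C@H](CO)[C@@H](O)[C@H]2O)c1=N` also reached only a limit, > 100 mg/kg. Within the data shown here, compound 2 therefore stands where the whole set stands at present, (the limit of > 100 mg/kg in this assay, at which 2 of the 2 values shown sit), and no step between measured compounds can be read from these results.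

Compound 3 `Cn1c(=O)[nH]c2c(nc(N)n2C2O[C@H](CO)[C@@H](O)[C@H]2O)c1=N` differs from compound 2 in one place: amino in place of bromo on an aromatic carbon, between two ring nitrogen atoms of the five-membered aromatic ring (amino in place of bromo on an aromatic carbon). Among the measured compounds shown here, the data hold no measured example of this exchange, and they give neither a size nor a direction for it. Resting only on compound 2 at its limit of > 100 mg/kg, no shift beyond the scatter is expected in this assay, and another limit is the likeliest report. The expected change is a step that the limit leaves unreadable from compound 2 to compound 3, and this is an estimate only. For compound 3 the expected dose for half-maximal effect is 120 mg/kg, with an estimated range from 40 mg/kg to 300 mg/kg.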

Compound 3, dose for half-maximal effect: > 100 mg/kg
Compound 3 ended at the assay's limit (the forecaster's own chance of this, stated with the estimate: 75%); the middle value does not contradict the limit.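

No step from compound 2 to compound 3 can be read in this assay, since both compounds ended at a limit rather than a number: the limit of > 100 mg/kg in this assay, at which 3 of the 3 values shown sit.

The compounds shown leave open whether amino in place of bromo on an aromatic carbon changes the dose for half-maximal effect at all, and in which direction.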